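Methylating a Phenol on a Shared Isoquinoline-Type Core

The source may report more compounds than this note shows. Statements on the series, on what has been measured and on what is new or still open speak of the compounds shown alone.

Measured compounds:
compound 1 `COc1ccc(-c2cc3ccccc3c(-c3ccc(O)cc3)n2)cc1` — > 50000 nM
compound 2 `COc1ccc(-c2cc3ccccc3c(-c3ccc(OC)cc3)n2)cc1` — > 50000 nM
compound 3 `COc1ccc(-c2cc3cc(C)ccc3c(-c3ccc(O)cc3)n2)cc1OC` — 5980 nM

Of the compounds shown here, three have been tested in a functional assay on DU-145 cells (Homo sapiens) for cytotoxicity, read by CCK-8 assay and cell counting, with a stated time of 72 h; a higher number here means a weaker inhibitor, a lower number a stronger inhibitor. Compound 1 gives > 50000 nM, which is a limit of the assay and not a number. Compound 2 likewise gives > 50000 nM, again a limit. Among the measured compounds shown here, compound 3 is the only one with a measured number, 5980 nM in this assay. Compound 2 differs from compound 1 by methyl in place of hydrogen on an oxygen on an aromatic ring; the step that the two limits leave unreadable from compound 1 to compound 2 cannot be sized, because the limit of > 50000 nM in this assay, at which 2 of the 3 values shown sit, holds both values. Compound 4 `COc1ccc(-c2nc(-c3ccc(OC)c(OC)c3)cc3cc(C)ccc23)cc1` has not been measured. It differs from compound 3 by methyl in place of hydrogen on an oxygen on an aromatic ring, the same kind of change as from compound 1 to compound 2. The difference between the core of compound 3 and the core of compound 1 is not broken down here. Since the earlier step is unreadable, the expectation for compound 4 rests only on compound 3 and its value 5980 nM: a step of a 2.0-fold higher number from compound 3 to compound 4 (0.30 log units; within the scatter) is estimated, toward somewhat weaker inhibition. Compound 4 is therefore expected to give about 12000 nM, with a plausible range from 4000 nM to 50000 nM in this assay.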

Compound 4, half-maximal inhibitory concentration: > 50000 nM
Compound 4 ended at the assay's limit (the forecaster's own chance of this, stated with the estimate: 35%); at least 4.1-fold (0.61 log units) between middle value and limit.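

In this assay, putting methyl in place of hydrogen on the oxygen, which turns hydroxy into methoxy, gives on the core of compound 3 an at least 8.3-fold higher number from compound 3 to compound 4 (0.92 log units; beyond the scatter), so on this core the change clearly weakens the result. Compound 4 gives > 50000 nM, which is a limit of the assay and not a number. The same change on the core of compound 1 cannot be read, so this series does not show whether the effect carries from one core to the other, because both values there rest on a limit: the limit of > 50000 nM in this assay, at which 3 of the 4 values shown sit.

The compounds shown leave open whether only the hydroxy group itself gives the measurable value of compound 3, or whether an amine, a carboxylic acid or a longer chain such as ethoxy in its place would also do so. Also open is which of the differences between the two cores matters, since no pair shown separates them.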